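Ester side-chain variation on a shared core

A few compounds are considered here, and "the series" means these few. Any claim that something is new, unique, unknown or untested is made for them only; others in the source may bear on it.

Compound 1 `COC(=O)C1=C(C)NC(C)=C(C(=O)OCC2CC2)C1c1cccc([N+](=O)[O-])c1` gives 21 nM in a functional assay on HEK293 cells for antagonist activity at Voltage-dependent L-type calcium channel subunit alpha-1D (Rattus norvegicus), read by FLIPR (on this read-out higher numbers stand for weaker inhibition and lower numbers for stronger inhibition), and stands at the lowest of the two numbers recorded so far. Going by the values given here, compound 2 `CCOC(=O)C1=C(C)NC(C)=C(C(=O)OC=O)C1c1cccc([N+](=O)[O-])c1` gives 13900 nM in this assay, a far higher number, beyond the scatter; no single-point step connects these two, so only their values can be set side by side.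

Compound 3 `COC(=O)C1=C(C)NC(C)=C(C(=O)OCc2ccc(OC)c(OC)c2)C1c1cccc([N+](=O)[O-])c1` is not yet measured. Against compound 1 the change is 3,4-dimethoxyphenyl in place of cyclopropyl on a saturated chain carbon bound to an oxygen next to a carbonyl group, with everything else on the shared core kept. Compound 3 is expected to stay close to the strong inhibition of compound 1, the expected step of a 1.4-fold higher number from compound 1 to compound 3 (0.15 log units; within the scatter) being small and within the scatter, its direction uncertain. For compound 3 the estimate in this assay is 30 nM, with a range from 8 nM to 120 nM.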

Compound 3, half-maximal inhibitory concentration: 117 nM
The estimate for compound 3 lay 3.9-fold (0.59 log units) below the measured number, and the stated range covers the measured number.
By their numbers in this assay, from the lowest: compound 1; then compound 3; then compound 2.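

Going by these compounds alone, on a saturated chain carbon bound to an oxygen next to a carbonyl group, 3,4-dimethoxyphenyl in place of cyclopropyl gives the first single-place step in this assay: a 5.6-fold higher number from compound 1 to compound 3 (0.75 log units; beyond the scatter). This change is beyond the scatter and points to weaker inhibition, yet compound 3 still gives 117 nM, so this position accepts the 3,4-dimethoxybenzyl group with a modest loss and not a collapse of inhibition. No available measurement bears on what lies behind the step.

Still open, on these data alone, is whether the step follows the aromatic ring itself or the two methoxy groups on it. A plain benzyl group or a chain ending in an amine at this place would show how far the trend holds beyond this single pair.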